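Halogen swap on the aryl-bearing triazole thiol

The source may report more compounds than this note shows. Statements on the series, on what has been measured and on what is new or still open speak of the compounds shown alone.

Compound 3 `Sc1nnc(COc2ccc(-c3ccccc3)cc2)n1-c1ccc(Cl)cc1` stands lowest of the three numbers in a functional assay on the whole organism (strain Wistar) for inhibition, with Rattus norvegicus as the target, read by paw edema, with a stated time of 4 h, at a dose of 10 mg/kg by the oral route (a lower number here means less inhibition, a higher number more inhibition at the dose given (going by the name of the read-out)), where compound 3 gives 18.2%. Among the compounds with values here, compound 2 `CCCCn1c(S)nnc1COc1ccc(-c2ccccc2)cc1` gives 81.8% in this assay, and the single step of a number 63.6 percentage points lower from compound 2 to compound 3 (beyond the scatter), a 4-chlorophenyl in place of butyl on an aromatic nitrogen, accounts for the gap. Compound 1 `Fc1ccc(Nc2nnc(COc3ccc(-c4ccccc4)cc3)o2)cc1` gives 52.3% in this assay; it carries a 4-fluorophenyl but on a different core, so only its value is available. Compound 4 `Fc1ccc(-n2c(S)nnc2COc2ccc(-c3ccccc3)cc2)cc1` differs from compound 3 as follows: fluoro in place of chloro on an aromatic carbon. Within the data shown here, no measured step bears on this change; the one measured step concerns the aryl itself, not its halogen. Compound 4 is expected to show a step of a number 6.8 percentage points higher from compound 3 to compound 4 (within the scatter), within the scatter, and an estimated value of 25%, in the range 8% to 45%.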

Compound 4, a percentage reported as inhibition, in the whole organism at one dose (the size of the read-out at that dose, not a potency): 79.5%
The estimate for compound 4 lay 54.5 percentage points below the measured number; the whole stated range lies below it.
By their numbers in this assay, from the lowest: compound 3; then compound 1; then compounds 4 and 2 (each within the scatter of the next).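

Changing only the halogen gives a number 61.3 percentage points higher from compound 3 to compound 4 (beyond the scatter) in this assay, so this position is sensitive to chloro versus fluoro. An aryl group on the aromatic nitrogen is not in itself the source of the loss seen with compound 3, as 4-fluorophenyl in place of butyl gives a number 2.3 percentage points lower from compound 2 to compound 4 (within the scatter). Nothing at hand explains the difference between the two halogens.

On these data alone, whether bromo, methyl, methoxy or an unsubstituted phenyl follows chloro or fluoro remains open. So does the effect of chloro in place of fluoro on the core of compound 1.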